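The source may hold more compounds than are shown below. What is called first, only, known or untested is meant among the compounds shown, and "the series" means these compounds.

Values in a functional assay on SK-HEP1 cells (Homo sapiens) for inhibition, read by MTT assay, with a stated time of 72 h; a lower number here means a stronger inhibitor, a higher number a weaker inhibitor:
- compound 1 `Nc1ncnc2c1c(-c1cnc3[nH]ccc3c1)nn2CCCCCCCCC(=O)NO`: 11200 nM
- compound 2 `Nc1nc2cc(-c3nn(CCCCCCCCCC(=O)NO)c4ncnc(N)c34)ccc2o1`: 14100 nM
- compound 3 `Nc1nc2cc(-c3nn(CCCCCC(=O)NO)c4ncnc(N)c34)ccc2o1`: 3080 nM

Compound 3, at 3080 nM, has the lowest number of the three, and its gaps to the other two lie beyond the scatter. Compound 4 `Nc1nc2cc(-c3nn(CCCCCCCCC(=O)NO)c4ncnc(N)c34)ccc2o1` keeps the core of compound 3 and extends the chain: 3-(hydroxycarbamoyl)propyl in place of hydroxycarbamoyl on a saturated chain carbon, five bonds along the chain from an aromatic nitrogen. Among the compounds with values here, the only measured step that changes the chain on this core is a 4.6-fold lower number from compound 2 to compound 3 (0.66 log units; beyond the scatter), a modest one. The present change runs the opposite way and stops short of the chain of compound 2. With the chain of compound 4 on a different core, compound 1 gives 11200 nM. Three compounds establish no firm trend with chain length, so the estimate rests on these few values. The expected result in this assay is a 2.9-fold higher number from compound 3 to compound 4 (0.47 log units; beyond the scatter), somewhat smaller than the measured step and towards a weaker inhibitor. Compound 4 is estimated at 9000 nM, with an expected range of 4500 nM to 16000 nM.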

Compound 4, half-maximal inhibitory concentration: > 100000 nM
Compound 4 was reported as a limit; the forecaster's own chance of this, stated with the estimate: 2%; middle value at least 11-fold (1.04 log units) away from the limit.
By their numbers in this assay, from the lowest: compound 3; then compounds 1 and 2 (each within the scatter of the next). At a limit, above all of these: compound 4.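

Compound 4 is reported in this assay only as a limit, the only such value in the series: the limit of > 100000 nM in this assay, at which 1 of the 4 values shown sits.

On the shared core, the change to 3-(hydroxycarbamoyl)propyl gives an at least 32-fold higher number from compound 3 to compound 4 (1.51 log units; beyond the scatter), and the step from the longer chain gives an at least 7.0-fold higher number from compound 2 to compound 4 (0.85 log units; beyond the scatter), so the number does not rise steadily with chain length across these three compounds, and the intermediate chain of compound 4 reads highest. With the same chain on a different core, the comparison gives an at least 8.9-fold higher number from compound 1 to compound 4 (0.95 log units; beyond the scatter), so chain length alone does not set the result.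

The values give no reason for this sharp loss at one chain length on this core. Still open, from the compounds shown here alone, are other chain lengths between those of compound 3 and compound 2, and a carboxylic acid in place of the terminal hydroxycarbamoyl.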